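Replacing 4-chlorophenyl with 1,3-benzothiazol-2-yl on the amide

The source may report more compounds than this note shows. Statements on the series, on what has been measured and on what is new or still open speak of the compounds shown alone.

Measured so far in a functional assay on cells (Panel NCI-60 (60 carcinoma cell lines), Homo sapiens) for inhibition, read by colorimetric assay, with a stated time of 3 days; a lower number here means a stronger inhibitor of growth, a higher number a weaker inhibitor of growth:
Compound 1 `COc1ccc2sc(NC(=O)CCCCCCNC(=O)C(O)(O)C(F)(F)F)nc2c1`: 1230 nM
Compound 2 `O=C(CCCCCCNC(=O)C(O)(O)C(F)(F)F)Nc1ccc(Br)cc1`: 3160 nM
Compound 3 `O=C(CCCCCCNC(=O)C(O)(O)C(F)(F)F)Nc1ccc(Cl)cc1`: 5130 nM

In this assay the value of compound 3 lies within the scatter of compound 2, while compound 1 shows a lower number, beyond the scatter. The next compound, compound 4 `O=C(CCCCCCNC(=O)C(O)(O)C(F)(F)F)Nc1nc2ccccc2s1`, differs from compound 3 in one place: 1,3-benzothiazol-2-yl in place of 4-chlorophenyl on an amide-type nitrogen. Among the compounds with values here, the only measured step, a 1.6-fold higher number from compound 2 to compound 3 (0.21 log units; within the scatter), exchanges one halogen for another and does not test this change. The closer guide is compound 1 at 1230 nM, which carries 1,3-benzothiazol-2-yl on the amide-type nitrogen together with a methoxy group that compound 4 lacks. Within the data shown here, no measured step isolates that methoxy group, so only part of the gap to compound 1 is assumed. A modest move toward a lower number is expected, possibly within the scatter, and the estimated step is a 2.1-fold lower number from compound 3 to compound 4 (0.31 log units; beyond the scatter). For compound 4 the estimated value is 2500 nM, with an expected range of 1000 nM to 6000 nM.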

Compound 4, concentration for 50% growth inhibition: 3390 nM
The estimate for compound 4 lay 1.4-fold (0.13 log units) below the measured number; the range from low to high includes it.
By their numbers in this assay, from the lowest: compound 1; then compounds 2, 4 and 3 (each within the scatter of the next).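

In this assay, 1,3-benzothiazol-2-yl on the amide-type nitrogen does not by itself set compound 4 apart from the halogenated phenyl compounds, since both a 1.5-fold lower number from compound 3 to compound 4 (0.18 log units; within the scatter) and a 1.1-fold higher number from compound 2 to compound 4 (0.03 log units; within the scatter) stay within the scatter. The earlier compounds shown here could not show this. Compound 1 carried the new ring only together with its methoxy group. Removing that methoxy group gives a 2.8-fold higher number from compound 1 to compound 4 (0.44 log units; beyond the scatter) and is the only new step beyond the scatter, so among these compounds the lower number of compound 1 goes with the methoxy group and not with the ring exchange alone.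

Going by these compounds, it remains open whether an ethoxy group or a hydroxyl group on that aromatic carbon would give a similar step, and whether a longer chain would change the picture. Nothing measured here accounts for any of these steps.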